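Chloro for methyl on the aryl ring: working notes

The source may hold more compounds than are shown below. What is called first, only, known or untested is meant among the compounds shown, and "the series" means these compounds.

compound 1 `Cc1ccc(C2CNN=C2S(=O)(=O)CC2=NCCS2)cc1`: 42.2%
compound 2 `COc1ccc(C2=NOC(c3ccc(C)cc3)C2S(=O)(=O)CC2=NCCO2)cc1`: 66.6%
compound 3 `Cc1ccc(C2CNN=C2S(=O)(=O)CC2=NCCO2)cc1`: 42.1%

In a functional assay, tested at 75 ug/mL (a lower number here means a weaker effect, a higher number a stronger effect of the compound at the concentration tested), compound 1 stands second highest of the three numbers. Nearest is compound 3, a number 0.1 percentage points lower from compound 1 to compound 3 (within the scatter). Furthest is compound 2, whose value lies beyond the scatter from that of compound 1, but compound 2 differs from compound 1 in several places at once and yields no single step.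

Compound 4 `O=S(=O)(CC1=NCCS1)C1=NNCC1c1ccc(Cl)cc1` differs from compound 1 by chloro in place of methyl on an aromatic carbon. Going by the values given here, no measured step touches this part of the structure; the one measured step concerns the five-membered ring on the saturated chain carbon bound to the sulfonyl sulfur and was within the scatter. The step is therefore expected to be a number 0.2 percentage points lower from compound 1 to compound 4 (within the scatter), none beyond the scatter. Compound 4 is estimated at 42%, between 28% and 56%.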

Compound 4, a percentage reported as activity, at one concentration (the size of the read-out at that concentration, not a potency): "not active" (no number reported)
Compound 4 has no reported number here; the estimate stays without a comparison.
By their numbers in this assay, from the lowest: compounds 3 and 1 (each within the scatter of the next); then compound 2.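

Going by these compounds alone, compound 4 is reported as "not active" in this assay without a number, so no step from compound 1 to compound 4 can be read. The compounds shown leave open how far 4-methylphenyl to 4-chlorophenyl shifts the read-out. Nothing at hand accounts for this result.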